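Fluorophenyl position shift across two hydroxyphenyl cores

The source may hold more compounds than are shown below. What is called first, only, known or untested is meant among the compounds shown, and "the series" means these compounds.

Measured so far, in a functional assay on T47D cells (Homo sapiens) for inhibition; a lower number here means a stronger inhibitor, a higher number a weaker inhibitor:
compound 1 `Oc1cccc(-c2cc(-c3ccccc3F)cc(-c3cccc(O)c3)n2)c1`: 4370 nM
compound 2 `Oc1cccc(-c2cc(-c3cccc(F)c3)cc(-c3cccc(O)c3)n2)c1`: 21300 nM
compound 3 `Oc1ccc(-c2cc(-c3ccccc3F)cc(-c3ccc(O)cc3)n2)cc1`: 15100 nM

Compound 2 differs from compound 1 by 3-fluorophenyl in place of 2-fluorophenyl on an aromatic carbon. That change gave a 4.9-fold higher number from compound 1 to compound 2 (0.69 log units; beyond the scatter). The core of compound 3 differs from the core of compound 1, but that difference is not broken down here; in this assay compound 3 and compound 2 fall within the scatter of each other.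

Compound 4 `Oc1ccc(-c2cc(-c3cccc(F)c3)cc(-c3ccc(O)cc3)n2)cc1` is not yet measured. It differs from compound 3 by 3-fluorophenyl in place of 2-fluorophenyl on an aromatic carbon, the same kind of change as from compound 1 to compound 2, though here the place is meta to two 4-hydroxyphenyl groups rather than two 3-hydroxyphenyl groups. For the measured compounds named here, a step of similar size is expected, a 4.0-fold higher number from compound 3 to compound 4 (0.60 log units; beyond the scatter), resting on the single earlier step of a 4.9-fold higher number from compound 1 to compound 2 (0.69 log units; beyond the scatter). Compound 4 is therefore estimated at 60000 nM, with a range of 20000 nM to 180000 nM.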

Compound 4, half-maximal inhibitory concentration: > 50000 nM
Compound 4 gave a limit, no number; the forecaster's own chance of this, stated with the estimate: 25%; the middle value lies beyond the limit too.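

In this assay, 3-fluorophenyl in place of 2-fluorophenyl also gives a higher number on the second core: an at least 3.3-fold higher number from compound 3 to compound 4 (0.51 log units; beyond the scatter). Compound 4 reads > 50000 nM, which is a limit of the assay and not a number. The direction of the change therefore carries over between these two cores, but its size on the core of compound 3 is not fixed, and no difference between the two steps can be claimed: the same change on two cores in this assay, a 4.9-fold higher number (0.69 log units; beyond the scatter) from compound 1 to compound 2 and an at least 3.3-fold higher number (0.51 log units; beyond the scatter) from compound 3 to compound 4; the limit leaves it open whether they differ

Still open, as far as these compounds go, is how the change behaves on a core carrying one 3-hydroxyphenyl and one 4-hydroxyphenyl group. The compounds shown also do not tell what a chlorophenyl group in place of the fluorophenyl, or a methoxy group or an amine in place of the hydroxy groups, would give.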